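Ring-closed acid chain tested at the fatty acid receptor

The compounds below may be only part of what the source reports. "The series", "measured", "known", "first", "only" and "open" are said of these compounds alone.

compound 1 `Cc1c(C#Cc2ccc(CCC(=O)O)cc2)cc(Cl)nc1Cl`: 91%
compound 2 `O=C(O)CCc1ccc(C#Cc2cc(Cl)nc(Cl)c2)cc1`: 103%

In an in vitro functional assay on 1321-N1 cells for agonist activity at Free fatty acid receptor 1 (Homo sapiens), read by fluorescence, spectrophotometry and calcium flux (on this read-out higher numbers stand for larger maximal responses and lower numbers for smaller maximal responses), compound 2 gives 103%, the highest of the two numbers. Going by the values given here, the only measured step, a number 12 percentage points higher from compound 1 to compound 2 (beyond the scatter), came with hydrogen in place of methyl on an aromatic carbon. Compound 3 `O=C(O)C1CC1c1ccc(C#Cc2cc(Cl)nc(Cl)c2)cc1` differs from compound 2 by 2-carboxycyclopropyl in place of 2-carboxyethyl on an aromatic carbon. Among the compounds with values here, no measured step touches the 2-carboxyethyl chain or the three-membered ring, so none bears directly on this change. Compound 3 is therefore expected to stay close to compound 2, with a step of a number 8 percentage points lower from compound 2 to compound 3 (within the scatter) in this assay, inside the usual scatter. The estimate for compound 3 is 95%, ranging from 70% to 115%.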

Compound 3, largest response reached (reported as efficacy), in percent of the reference or control that the assay uses: 96%
The estimate for compound 3 lay 1 percentage points below the measured number; the measured number falls inside the stated range.
By their numbers in this assay, from the lowest: compounds 1, 3 and 2 (each within the scatter of the next, the first and the last beyond it).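

Swapping 2-carboxyethyl for 2-carboxycyclopropyl on the aromatic carbon para to a large group gives a number 7 percentage points lower from compound 2 to compound 3 (within the scatter) in this assay. The maximal response therefore tolerates tying the acid chain into a three-membered ring, something the earlier step, which changed only a methyl elsewhere on the core, could not show. No further data bear on why the response holds at this position.

The compounds shown leave open how a cyclobutane ring or a longer chain carrying the acid would behave here.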